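A few compounds are considered here, and "the series" means these few. Any claim that something is new, unique, unknown or untested is made for them only; others in the source may bear on it.

Of the compounds shown here, two on the shared core have been measured so far. In a functional assay on CHO cells for antagonist activity at sphingosine 1-phosphate receptor 2 (Homo sapiens), read by calcium flux (on this read-out lower numbers stand for stronger inhibition and higher numbers for weaker inhibition), compound 1 `O=C(O)Cn1nc(Cc2nc3cc(Cl)c(OCC(F)F)cc3[nH]2)c2ccccc2c1=O` gives 12 nM, and compound 2 `CCOc1cc2[nH]c(Cc3nn(CC(=O)O)c(=O)c4ccccc34)nc2cc1Cl` gives 17 nM. Among the measured compounds shown here, compound 2 thus holds the higher of the two numbers, with compound 1 as its only neighbour, but the step of a 1.4-fold higher number from compound 1 to compound 2 (0.15 log units; within the scatter) lies within the scatter, so the two stand together rather than apart.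

Compound 3 `COc1cc2[nH]c(Cc3nn(CC(=O)O)c(=O)c4ccccc34)nc2cc1Cl` is not yet measured. It differs from compound 2 by hydrogen in place of methyl on a saturated chain carbon bound to an oxygen on an aromatic ring. For the measured compounds named here, the one step already seen at this place, a 1.4-fold higher number from compound 1 to compound 2 (0.15 log units; within the scatter), also changed this chain and stayed within the scatter. On that basis no step beyond the scatter is expected in this assay on going from compound 2 to compound 3. For compound 3 the estimate is 20 nM, with a range of 8 nM to 50 nM, an expected step of a 1.2-fold higher number from compound 2 to compound 3 (0.07 log units; within the scatter).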

Compound 3, half-maximal inhibitory concentration: 61 nM
Beside the measured number, compound 3's estimate is 3.1-fold (0.48 log units) below it; the whole stated range lies below it.
By their numbers in this assay, from the lowest: compounds 1 and 2 (each within the scatter of the next); then compound 3.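

In this assay, among the compounds shown here, the change from ethoxy to methoxy gives a 3.6-fold higher number from compound 2 to compound 3 (0.55 log units; beyond the scatter) and is the first change on this chain to go beyond the scatter. Hydrogen in place of difluoromethyl on the same saturated chain carbon gives a 5.1-fold higher number from compound 1 to compound 3 (0.71 log units; beyond the scatter) as a modest step, so among these compounds, methyl and difluoromethyl at this place stand together, while hydrogen stands apart from both. No measurement at hand accounts for these steps.

On these data alone, it remains open whether a longer chain, such as propoxy, would stay with compound 1 and compound 2 or move away from them. Also open, as far as these compounds go, is how a hydroxy group or an amine in place of the ethoxy group would read out on the shared core.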